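This account rests on a few compounds, and the source may have more. Where it says the series, first, only, none or still open, it means among the compounds named here.

Among the compounds with values here, in a functional assay on HCT-116 cells (Homo sapiens) for inhibition, read by CCK-8 assay, with a stated time of 48 h (a lower number here means a stronger inhibitor, a higher number a weaker inhibitor), compound 3 `COc1ccc(-c2cc3nccc(-c4cc(OC)c(OC)c(OC)c4)n3n2)cc1` gives 404 nM, the lowest of the three numbers so far. Compound 1 `C=Cc1ccc(-c2cc3nccc(-c4cc(OC)c(OC)c(OC)c4)n3n2)cc1` stands higher at 1060 nM, and compound 2 `COc1cc(-c2ccnc3cc(-c4ccc(C(C)=O)cc4)nn23)cc(OC)c1OC` higher still at 4390 nM. Compound 4 `COc1cc(-c2ccnc3cc(-c4ccc(-c5cnn(C)c5)cc4)nn23)cc(OC)c1OC` keeps the shared core but carries 1-methyl-1H-pyrazol-4-yl in place of methoxy on an aromatic carbon. Within the data shown here, no measured compound carries this group, so the evidence is indirect. Methoxy gave the lower number in both comparisons, the modest 2.6-fold lower number from compound 1 to compound 3 (0.42 log units; beyond the scatter) and the large 11-fold lower number from compound 2 to compound 3 (1.04 log units; beyond the scatter), so a modest rise is expected in this assay on losing it. The expected step is a 2.2-fold higher number from compound 3 to compound 4 (0.35 log units; beyond the scatter). Compound 4 is estimated at 900 nM, with an expected range from 250 nM to 3500 nM.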

Compound 4, half-maximal inhibitory concentration: 2110 nM
The estimate for compound 4 lay 2.3-fold (0.37 log units) below the measured number; the range from low to high includes it.
By their numbers in this assay, from the lowest: compound 3; then compounds 1 and 4 (each within the scatter of the next); then compound 2.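

In this assay, within the data shown here, the only group here that brings a ring of its own to this place, para to a large group, does not hold the level of methoxy (a 5.2-fold higher number from compound 3 to compound 4 (0.72 log units; beyond the scatter)), yet it gives a lower number than acetyl (a 2.1-fold lower number from compound 2 to compound 4 (0.32 log units; beyond the scatter)). Against vinyl, the step stays inside the scatter (a 2.0-fold higher number from compound 1 to compound 4 (0.30 log units; within the scatter)), so the added five-membered aromatic ring leaves the number in the range of that small group. Nothing measured here gives a reason for these differences. From the compounds shown here alone, whether an amine, a hydroxyl or a longer ether chain at this place would match methoxy remains open.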